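This account rests on a few compounds, and the source may have more. Where it says the series, first, only, none or still open, it means among the compounds named here.

Of the compounds shown here, two built on a shared core have been measured in an assay on mitochondria from L6 cells (Rattus norvegicus) for activation, with a stated time of 90 min; on this read-out higher numbers stand for an effect only at larger amounts of compound and lower numbers for an effect already at smaller amounts. Compound 1 `Oc1nc2nonc2nc1Nc1ccc(OC(F)(F)F)c(Cl)c1` gives 3000 nM in this assay. Compound 2 `CCCCOc1ccc(Nc2nc3nonc3nc2O)cc1`, which carries a butoxy group, gives 3700 nM in this assay. These two numbers lie within the usual scatter of each other, so on this evidence they cannot be told apart.

Compound 3 `CCc1ccc(Nc2nc3nonc3nc2O)cc1` has not been measured. It differs from compound 2 in one place: ethyl in place of butoxy on an aromatic carbon. The site is an aromatic carbon of a six-membered aromatic ring of carbon only, para to a large group. For the measured compounds named here, no measured pair shows what this change does, so the expectation rests on compound 2 alone. The step of a 1.4-fold higher number from compound 2 to compound 3 (0.13 log units; within the scatter) is expected to be modest, toward a somewhat larger number, and may not exceed the scatter. Compound 3 is therefore estimated at 5000 nM, with a likely range from 2000 nM to 15000 nM.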

Compound 3, half-maximal effective concentration: 10700 nM
Estimate against measurement, compound 3: 2.1-fold (0.33 log units) below, and the stated range covers the measured number.
By their numbers in this assay, from the lowest: compounds 1 and 2 (each within the scatter of the next); then compound 3.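

In this assay, for the compounds shown here, the swap of butoxy for ethyl on this aromatic carbon gives a 2.9-fold higher number from compound 2 to compound 3 (0.46 log units; beyond the scatter) and is the first change at a single place that can be read on its own. It shows that the group at this position matters: with ethyl, a larger amount of compound is needed for the same effect than with butoxy. No measurement here bears on why the number rises.

The swap alters two things together, the length of the chain and the presence of its oxygen, so the compounds shown do not tell which of them goes with the step. Ethoxy or butyl on this carbon would separate the two, and a longer chain such as hexyloxy would show whether the trend continues beyond butoxy.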